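The source may report more compounds than this note shows. Statements on the series, on what has been measured and on what is new or still open speak of the compounds shown alone.

Values in a functional assay on SK-BR-3 cells (Homo sapiens) for cytotoxicity, read by sulforhodamine B assay, with a stated time of 3 days (on this read-out higher numbers stand for an effect only at larger amounts of compound and lower numbers for an effect already at smaller amounts), for the compounds measured so far:
compound 1 `CCOCc1c(C)coc1-c1ccc2c(c1OC)CCCC2(C)C` gives 19.8 uM
compound 2 `Cc1coc(-c2ccc3c(c2O)CCCC3(C)C)c1C(=O)O` gives 0.7 uM
compound 3 `Cc1coc(-c2ccc3c(c2O)CCCC3(C)C)c1CO` gives 21.3 uM

Compound 1 and compound 3 lie within the scatter of each other, while compound 2 stands far lower than both. Going from compound 1 to compound 4 `COc1c(-c2occ(C)c2COC(C)=O)ccc2c1CCCC2(C)C` puts acetyl in place of ethyl on an oxygen on a saturated carbon. For the measured compounds named here, no measured step covers this exchange. The only one available, a 30-fold higher number from compound 2 to compound 3 (1.48 log units; beyond the scatter), is large, but it is hydroxymethyl in place of carboxy on an aromatic carbon, so it bears on the change only indirectly. It sets the carboxy compound apart from compound 3, and compound 1 also has no carboxy. Compound 4 has none either, so no step beyond the scatter is expected in this assay. The estimated change is small, a 1.2-fold lower number from compound 1 to compound 4 (0.09 log units; within the scatter), and it lies in no firmly expected direction. For compound 4 the estimated value is 16 uM, with an expected range from 6 uM to 40 uM.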

Compound 4, concentration for half-maximal effect: 14 uM
The estimate for compound 4 lay 1.1-fold (0.06 log units) above the measured number, within the range that was stated.
By their numbers in this assay, from the lowest: compound 2; then compounds 4, 1 and 3 (each within the scatter of the next).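

In this assay the exchange gives a 1.4-fold lower number from compound 1 to compound 4 (0.15 log units; within the scatter) and so stays within the scatter. For the compounds shown here, this is the first direct reading at this position: ethoxymethyl and acetoxymethyl cannot be told apart here, although acetyl brings a carbonyl and one more hydrogen-bond acceptor by count, so this exchange does not reproduce the large kind of step seen on the aromatic carbon, a 30-fold higher number from compound 2 to compound 3 (1.48 log units; beyond the scatter). No measurement at hand explains the result or assigns any property to either group.

The compounds shown leave open whether an amine, a carboxylic acid or a longer chain such as butyl on this oxygen would move the number beyond the scatter. Also open, going by these compounds, is whether the same exchange would read alike on the core of compound 2.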